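Amino to hydroxy on the aryl group of the shared core

The source may report more compounds than this note shows. Statements on the series, on what has been measured and on what is new or still open speak of the compounds shown alone.

Measured compounds:
compound 1 `Cc1ncc([N+](=O)[O-])n1CCSc1nnc(-c2ccccc2N)o1`: 35100 nM
compound 2 `Cc1ncc([N+](=O)[O-])n1CCSc1nnc(-c2ccc([N+](=O)[O-])cc2)o1`: 12200 nM

In a functional assay on SGC-7901 cells (Homo sapiens) for cytotoxicity, read by MTT assay, with a stated time of 48 h (a lower number here means a stronger inhibitor, a higher number a weaker inhibitor), compound 1 gives 35100 nM, the highest of the two numbers; compound 2 gives 12200 nM, a lower number beyond the scatter. Compound 3 `Cc1ncc([N+](=O)[O-])n1CCSc1nnc(-c2ccccc2O)o1` is not yet measured. It differs from compound 1 by hydroxy in place of amino on an aromatic carbon. Within the data shown here, no step between measured compounds speaks to this exchange, so little is expected of it in this assay: a step from compound 1 to compound 3 of a 1.2-fold lower number from compound 1 to compound 3 (0.07 log units; within the scatter) is estimated, not beyond the scatter in either direction. Compound 3 is therefore expected to give about 30000 nM, within 10000 nM to 90000 nM.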

Compound 3, half-maximal inhibitory concentration: 30500 nM
The estimate for compound 3 lay 1.0-fold (0.01 log units) below the measured number; the range from low to high includes it.
By their numbers in this assay, from the lowest: compound 2; then compounds 3 and 1 (each within the scatter of the next).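

Swapping amino for hydroxy on the aromatic carbon ortho to a large group gives a 1.2-fold lower number from compound 1 to compound 3 (0.06 log units; within the scatter) in this assay and is the first reading of this exchange in the series. At this position, 2-aminophenyl to 2-hydroxyphenyl does not separate the two compounds, and each group counts one hydrogen-bond donor and one hydrogen-bond acceptor. No measured evidence bears on this result.

Still open, going by these compounds, is whether a methoxy group or a carboxylic acid at this position would shift the number beyond the scatter.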